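The compounds below may be only part of what the source reports. "The series", "measured", "known", "first", "only" and "open" are said of these compounds alone.

Measured so far:
compound 1, `N#CCCn1nc(-c2ccc(OCc3ccc(Cl)cc3)cc2)oc1=S`: 2700 nM
compound 2, `N#CCCN1N=C(c2ccc(OCc3ccccc3)cc2)OCC1=O`: 160000 nM

In an assay for inhibition of Amine oxidase [flavin-containing] A (Rattus norvegicus) (on this read-out higher numbers stand for weaker inhibition and lower numbers for stronger inhibition), compound 2 gives 160000 nM, the highest of the two numbers shown. The nearest is compound 1, which in this assay gives 2700 nM, a much lower number, and that gap lies beyond the scatter. Going by the values given here, no step between measured compounds that differ in only one place is available, so this pair shows only what its two values are.

Compound 3, `N#CCCN1N=C(c2ccc(OCc3ccc([N+](=O)[O-])cc3)cc2)OCC1=O`, has not yet been measured in this assay. It differs from compound 2 by nitro in place of hydrogen on an aromatic carbon. Among the compounds with values here, no measured pair isolates this change on the shared core of compound 2 and compound 3, so the expectation rests on little. A modest step toward a lower number is expected, with a fair chance that it stays within the scatter. Compound 3 is estimated at 60000 nM, with a range from 15000 nM to 250000 nM. The expected step is a 2.7-fold lower number from compound 2 to compound 3 (0.43 log units; beyond the scatter).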

Compound 3, half-maximal inhibitory concentration: 2000 nM
For compound 3 the middle estimate is 30-fold (1.48 log units) above the measured one; the measured number lies below the stated range.
By their numbers in this assay, from the lowest: compounds 3 and 1 (each within the scatter of the next); then compound 2.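

Going by these compounds alone, compound 2 and compound 3 differ in one place only, so this pair gives the first change here that can be read on its own: in this assay, putting nitro in place of hydrogen, para to a large group, gives an 80-fold lower number from compound 2 to compound 3 (1.90 log units; beyond the scatter). This position is therefore sensitive to what stands on it, since one added group moves the read-out far toward stronger inhibition, and the step lies well beyond the scatter.

No measurement shown here explains the size of this step. On these data alone, with only nitro and hydrogen compared at this place on the shared core, it remains open whether another group there, such as an amine, a methoxy group or a carboxylic acid, would give a similar step or whether this one is particular to nitro.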